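This account rests on a few compounds, and the source may have more. Where it says the series, first, only, none or still open, it means among the compounds named here.

Compound 1 `CCNC(=O)C1=C(C)NC(=O)NC1c1ccco1`: 3%
Compound 2 `CC1=C(C(=O)NC(C)C)C(c2ccco2)NC(=O)N1`: 4%
Compound 3 `CCSC(=O)C1=C(C)NC(=O)NC1c1ccco1`: 14%

All three numbers come from an assay on membranes from HeLa cells for displacement of a labelled ligand from adenosine receptor A3 (Homo sapiens), read by scintillation counting, with a stated time of 180 min, tested at 1 uM (a higher number here means more inhibition at the concentration tested (going by the name of the read-out), a lower number less inhibition), and all are low. Of the three, compound 3 gives the largest number; against compound 2 the step of a number 10 percentage points higher from compound 2 to compound 3 (within the scatter) stays within the scatter, against compound 1 the step of a number 11 percentage points higher from compound 1 to compound 3 (beyond the scatter) is beyond it, though modest. The step from compound 1 to compound 2, a number 1 percentage points higher from compound 1 to compound 2 (within the scatter), is within the scatter.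

Compound 4 `CC1=C(C(=O)OC2CCCCC2)C(c2ccco2)NC(=O)N1` is the next one to be measured. It differs from compound 3 in one place: cyclohexyloxy in place of ethylsulfanyl on a carbonyl carbon. The measured steps that bear on this all end at compound 3: in both, an amino group on the carbonyl carbon is exchanged for ethylsulfanyl, and the gain was modest, at most a number 11 percentage points higher from compound 1 to compound 3 (beyond the scatter). Among the compounds with values here, no measured step exchanges ethylsulfanyl for an oxygen-bound group, so the bearing is only indirect, and nothing shows how a cyclohexyloxy group on this carbonyl carbon behaves. The expectation is therefore a step of no clear direction, most likely within the scatter, estimated as a number 2 percentage points lower from compound 3 to compound 4 (within the scatter). Compound 4 is expected to give 12% in this assay, with a range from 0% to 30%.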

Compound 4, a percentage reported as inhibition, at one concentration (the size of the read-out at that concentration, not a potency): 4%
For compound 4 the middle estimate is 8 percentage points above the measured one, within the range that was stated.
By their numbers in this assay, from the lowest: compounds 1, 2, 4 and 3 (each within the scatter of the next, the first and the last beyond it).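

In this assay, within the data shown here, the first oxygen-bound group on this carbonyl carbon gives no readable change from the sulfur-bound one: the step of a number 10 percentage points lower from compound 3 to compound 4 (within the scatter) leaves cyclohexyloxy and ethylsulfanyl unseparated, even with a six-membered ring of carbon entering in place of an open chain. Against the amino groups the result is the same, with no change at the digits printed from compound 2 to compound 4 (within the scatter) and a number 1 percentage points higher from compound 1 to compound 4 (within the scatter) both leaving compound 4 unseparated, so it cannot be assigned to either side of the one step that lies beyond the scatter, a number 11 percentage points higher from compound 1 to compound 3 (beyond the scatter) in this series. No supporting data on the cause of these results are available.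

Open, from the compounds shown here alone, is whether ethoxy, the direct oxygen counterpart of ethylsulfanyl, would stay with compound 3 or with compound 1 in this assay, which would separate the effect of the exchanged atom from that of the cyclohexyl ring. Also open, going by these compounds, is whether a carboxylic acid or a longer chain on this carbonyl carbon would lift the number clear of the low values seen for all four compounds.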